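Swapping a Hydroxy Chain for a Methyl Ester

A few compounds are considered here, and "the series" means these few. Any claim that something is new, unique, unknown or untested is made for them only; others in the source may bear on it.

Three related compounds share one core and differ only in the side chain on the ring. Compound 1 `CC(C)(C)[Si](C)(C)O[C@H]1CCCO[C@@H]1CCO` gives 46000 nM in a functional assay on HL-60 cells (Homo sapiens); a higher number here means a weaker inhibitor of growth, a lower number a stronger inhibitor of growth. Compound 2 `CC(C)(C)[Si](C)(C)O[C@H]1CCCO[C@@H]1CC=O` gives 40000 nM, and compound 3 `CC(C)(C)[Si](C)(C)O[C@H]1CCCO[C@@H]1C/C=C/CO` gives 27000 nM, the lowest number of the three, although every gap among them lies within the scatter: a 1.2-fold lower number from compound 1 to compound 2 (0.06 log units; within the scatter), a 1.7-fold lower number from compound 1 to compound 3 (0.23 log units; within the scatter) and a 1.5-fold lower number from compound 2 to compound 3 (0.17 log units; within the scatter). Compound 4 `COC(=O)/C=C/[C@H]1OCCC[C@@H]1O[Si](C)(C)C(C)(C)C` carries the change (2-(methoxycarbonyl)ethenyl in place of 4-hydroxybut-2-en-1-yl on a saturated ring carbon). Each earlier change at this chain left the number within the scatter, so a similarly small step, with no clear direction, is expected here: no change at the digits printed from compound 3 to compound 4 (within the scatter). Compound 4 is therefore expected to give about 27000 nM, with a likely range from 9000 nM to 80000 nM.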

Compound 4, concentration for 50% growth inhibition: 22000 nM
Compound 4: the middle estimate sits 1.2-fold (0.09 log units) above what was measured; the range from low to high includes it.
By their numbers in this assay, from the lowest: compounds 4, 3, 2 and 1 (each within the scatter of the next, the first and the last beyond it).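

In this assay, the 2-(methoxycarbonyl)ethenyl group, which has no hydrogen-bond donor, can replace 4-hydroxybut-2-en-1-yl with a result within the scatter (a 1.2-fold lower number from compound 3 to compound 4 (0.09 log units; within the scatter)), and formylmethyl likewise (a 1.8-fold lower number from compound 2 to compound 4 (0.26 log units; within the scatter)). Against 2-hydroxyethyl, the change gives the first step beyond the scatter among these compounds, though a modest one (a 2.1-fold lower number from compound 1 to compound 4 (0.32 log units; beyond the scatter)). Open, on these data alone, is whether a carboxylic acid, an amide or a longer chain at this ring carbon would move the number further. No measurement at hand explains these steps.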